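The source may hold more compounds than are shown below. What is called first, only, known or untested is meant among the compounds shown, and "the series" means these compounds.

Compound 1 `COc1cc(/C=C/c2ccc(NC(=O)/C=C/c3ccc(OC)c(OC)c3)cc2)cc(OC)c1` gives 960 nM in a functional assay on HT-29 cells (Homo sapiens) for inhibition, read by MTT assay, with a stated time of 48 h; on this read-out higher numbers stand for weaker inhibition and lower numbers for stronger inhibition.
Compound 2 `COc1cc(/C=C/c2ccc(NC(=O)/C=C/c3ccc(C#N)cc3)cc2)cc(OC)c1` gives 3320 nM in this assay.
Compound 3 `COc1cc(/C=C/c2ccc(NC(=O)/C=C/c3cccc(F)c3)cc2)cc(OC)c1` gives 16800 nM in this assay.

Compound 3 stands highest of the three, so it inhibits least: an 18-fold higher number from compound 1 to compound 3 (1.24 log units; beyond the scatter) and a 5.1-fold higher number from compound 2 to compound 3 (0.70 log units; beyond the scatter). Compound 4 `COc1cc(/C=C/c2ccc(NC(=O)/C=C/c3ccc(Br)cc3)cc2)cc(OC)c1` is not yet measured; it differs from compound 3 by 4-bromophenyl in place of 3-fluorophenyl on a double-bonded chain carbon bound to a double-bonded chain carbon. All three measured steps change the aryl group at this same place, and all were beyond the scatter: a 3.5-fold higher number from compound 1 to compound 2 (0.54 log units; beyond the scatter), an 18-fold higher number from compound 1 to compound 3 (1.24 log units; beyond the scatter), a 5.1-fold higher number from compound 2 to compound 3 (0.70 log units; beyond the scatter). None exchanges one halogen for another, so the direction is uncertain; compound 2, with its 4-cyanophenyl, gives 3320 nM, below compound 3. A modest drop is therefore expected in this assay. Compound 4 is estimated at 6000 nM, between 1500 nM and 25000 nM, an expected step of a 2.8-fold lower number from compound 3 to compound 4 (0.45 log units; beyond the scatter).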

Compound 4, half-maximal inhibitory concentration: 5260 nM
Estimate against measurement, compound 4: 1.1-fold (0.06 log units) above, and the stated range covers the measured number.
By their numbers in this assay, from the lowest: compound 1; then compounds 2 and 4 (each within the scatter of the next); then compound 3.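

In this assay, the step of a 3.2-fold lower number from compound 3 to compound 4 (0.50 log units; beyond the scatter) swaps the halogen and moves it at once, so the two changes cannot be separated. Bromo and cyano on this ring cannot be told apart, given a 1.6-fold higher number from compound 2 to compound 4 (0.20 log units; within the scatter). The 3,4-dimethoxyphenyl ring remains ahead of the 4-bromophenyl ring, with a 5.5-fold higher number from compound 1 to compound 4 (0.74 log units; beyond the scatter) as the gap. No measurement shown here explains these differences. Still open, from the compounds shown here alone, is how a 4-fluorophenyl ring would compare, which would separate the halogen's identity from its place, and how a ring carrying an amine would behave.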